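The source may report more compounds than this note shows. Statements on the series, on what has been measured and on what is new or still open speak of the compounds shown alone.

Working notes on the series in a functional assay on PANC-1 cells (Homo sapiens) for inhibition, read by MTT assay, with a stated time of 24 h, tested at 10 uM; a higher number here means more inhibition at the concentration tested (going by the name of the read-out), a lower number less inhibition. Compound 1, `CCOc1cc(=O)n(CCCO)c2c1CC(CC=C(C)C)C(C)(C)C2`, gives 16.6%. Compound 2, `COc1ccc(C(=O)NCCCOc2cc(=O)n(CCCO)c3c2CC(CC=C(C)C)C(C)(C)C3)cc1`, gives 2.5%, and compound 3, `CC(C)=CCC1Cc2c(OCCCNC(=O)c3cccs3)cc(=O)n(CCCO)c2CC1(C)C`, gives 5.6%. Compound 2 stands lowest of the three: the step of a number 14.1 percentage points lower from compound 1 to compound 2 (beyond the scatter) lies beyond the scatter, while the step of a number 3.1 percentage points higher from compound 2 to compound 3 (within the scatter) lies within it, so compound 2 and compound 3 cannot be ordered against each other. The companion step a number 11 percentage points lower from compound 1 to compound 3 (beyond the scatter) is likewise beyond the scatter.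

Compound 4 is `COc1ccc(C(=O)NCCCOc2cc(=O)n(CCCO)c3c2CC(C/C=C(\C)CCC=C(C)C)C(C)(C)C3)cc1`. The change from compound 2 is 3-methylbut-2-en-1-yl in place of hydrogen on a saturated chain carbon bound to a double-bonded chain carbon. Among the compounds with values here, none of the measured steps touches this place: two of them alter the substituent on the saturated chain carbon two bonds along the chain from an oxygen on an aromatic ring, and the third exchanges thiophen-2-yl for 4-methoxyphenyl on a carbonyl carbon. Within the data shown here, no measured step therefore bears on the lengthening of 3-methylbut-2-en-1-yl to 3,7-dimethylocta-2,6-dien-1-yl, and no step beyond the scatter is expected in either direction. For compound 4 the estimate in this assay is 5%, between -6% and 18%. The expected step is a number 2.5 percentage points higher from compound 2 to compound 4 (within the scatter), inside the scatter.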

Compound 4, a percentage reported as inhibition, at one concentration (the size of the read-out at that concentration, not a potency): 14.1%
Estimate against measurement, compound 4: 9.1 percentage points below, within the range that was stated.
By their numbers in this assay, from the lowest: compounds 2, 3, 4 and 1 (each within the scatter of the next, the first and the last beyond it).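

In this assay, within the data shown here, the lengthening of 3-methylbut-2-en-1-yl to 3,7-dimethylocta-2,6-dien-1-yl appears as a number 11.6 percentage points higher from compound 2 to compound 4 (beyond the scatter) and shows that this chain on the shared core can move the read-out, which the earlier compounds could not show since all of them carry 3-methylbut-2-en-1-yl. The step is modest and rests on a single pair, with the 4-methoxyphenyl amide held in place. Nothing at hand gives a reason for this step.

From the compounds shown here alone, whether the same lengthening gives a step of like size on the thiophen-2-yl amide of compound 3, or on compound 1, stays open. Also open, going by these compounds, is what a fully saturated chain, or a chain ending in a carboxylic acid or an amine, would give at this place.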